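E versus Z butenyl linkers on alkynyl uracils

A few compounds are considered here, and "the series" means these few. Any claim that something is new, unique, unknown or untested is made for them only; others in the source may bear on it.

compound 1 `CCCCCC#Cc1cn(C/C=C/CN2C(=O)c3ccccc3C2=O)c(=O)[nH]c1=O` — > 500000 nM
compound 2 `CCCCC#Cc1cn(C/C=C\CN2C(=O)c3ccccc3C2=O)c(=O)[nH]c1=O` — 41000 nM

Within the data shown here, in a functional assay on MOLT-4 cells (Homo sapiens) for antiproliferative activity, read by MTT assay, with a stated time of 3 days (on this read-out higher numbers stand for weaker inhibition and lower numbers for stronger inhibition), compound 2 gives 41000 nM, the only true number among the values shown. For compound 1 the result is a limit of the assay, > 500000 nM. Compound 3 `CCCCC#Cc1cn(C/C=C/CN2C(=O)c3ccccc3C2=O)c(=O)[nH]c1=O` remains to be measured; it differs from compound 2 in that (the two compounds have the same atoms and bonds and differ only in configuration as drawn: 1 of 1 stereo elements differ; a double bond is drawn Z in compound 2 and E in compound 3). Among the measured compounds shown here, no step between two measured compounds is available to calibrate this change. The other compound drawn with an E double bond, compound 1, sits at the limit of > 500000 nM in this assay, at which 1 of the 2 values shown sits. The step from compound 2 to compound 3 is therefore expected to weaken inhibition, roughly a 3.7-fold higher number from compound 2 to compound 3 (0.56 log units; beyond the scatter). Compound 3 is estimated at 150000 nM, within 30000 nM to 500000 nM, with a real chance that only a limit is reported.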

Compound 3, half-maximal inhibitory concentration: 171000 nM
For compound 3 the middle estimate is 1.1-fold (0.06 log units) below the measured one; low and high end bracket the measured number.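

With the chain held constant, the E double bond of compound 3 gives weaker inhibition than the Z double bond of compound 2 in this assay (a 4.2-fold higher number from compound 2 to compound 3 (0.62 log units; beyond the scatter)), a step set by the double bond alone: the fact that compounds 2 and 3 differ only in the configuration as drawn. Among the E compounds, hydrogen in place of methyl on a saturated chain carbon, four bonds along the chain from a triple-bonded carbon, also registers (an at least 2.9-fold lower number from compound 1 to compound 3 (0.46 log units; beyond the scatter)). That step rests on a limit for compound 1: the limit of > 500000 nM in this assay, at which 1 of the 3 values shown sits.

Open, going by these compounds, is whether the gap between Z and E holds for other groups on the triple bond, such as a longer chain or a chain ending in an amine.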